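Halogen swap on the anilino ring of a quinoline thiosemicarbazone

The source may report more compounds than this note shows. Statements on the series, on what has been measured and on what is new or still open speak of the compounds shown alone.

Of the compounds shown here, three sharing one core have been tested in a functional assay on SGC-7901 cells (Homo sapiens) for antiproliferative activity, read by sulforhodamine B assay, with a stated time of 72 h; on this read-out lower numbers stand for stronger inhibition and higher numbers for weaker inhibition. Compound 1 `Fc1ccccc1NC(=S)N/N=C/c1ccc2ccccc2n1` and compound 2 `S=C(N/N=C/c1ccc2ccccc2n1)Nc1ccccc1Br` carry a 2-fluorophenyl and a 2-bromophenyl on the amide-type nitrogen. In this assay compound 1 gives > 100000 nM, which is a limit of the assay and not a number. Compound 2 likewise gives > 100000 nM, again a limit. Compound 3 `S=C(N/N=C/c1ccc2ccccc2n1)Nc1ccc(Br)cc1` differs from compound 2 in that (4-bromophenyl in place of 2-bromophenyl on an amide-type nitrogen). In this assay, going by the values given here, compound 3 is the only one to return a number, 69400 nM. The step of an at least 1.4-fold lower number from compound 2 to compound 3 (0.15 log units; that floor lies within the scatter) and the step of an at least 1.4-fold lower number from compound 1 to compound 3 (0.15 log units; that floor lies within the scatter) can be read only as floors. The step that the two limits leave unreadable from compound 2 to compound 1 cannot be read at all because the limit of > 100000 nM in this assay, at which 2 of the 3 values shown sit, hides both ends.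

The change fluoro in place of bromo on an aromatic carbon is the same kind of change as fluoro in place of bromo on an aromatic carbon, which leads to compound 4 `Fc1ccc(NC(=S)N/N=C/c2ccc3ccccc3n2)cc1`; the two differ in that one sits ortho to a large group and the other para to a large group. The earlier halogen swap gave no readable step, so the expectation for compound 4 rests only on compound 3 and its value of 69400 nM. The step of a 1.3-fold higher number from compound 3 to compound 4 (0.11 log units; within the scatter) is estimated to be small, and compound 4 is expected to sit near 90000 nM in this assay, between 35000 nM and 250000 nM.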

Compound 4, half-maximal inhibitory concentration: 32300 nM
Compound 4: middle estimate off by 2.8-fold (0.45 log units), on the high side; the measured number lies below the stated range.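

In this assay, going by these compounds alone, fluoro in place of bromo on an aromatic carbon, para to a large group, gives a 2.1-fold lower number from compound 3 to compound 4 (0.33 log units; beyond the scatter), which is the only direct reading of this swap and rests on a single pair. Replacing the 2-halophenyl groups with 4-fluorophenyl gives an at least 3.0-fold lower number from compound 2 to compound 4 (0.49 log units; beyond the scatter) and an at least 3.0-fold lower number from compound 1 to compound 4 (0.49 log units; beyond the scatter); both are floors, so they fix only the least size of these steps and say nothing of how far each one truly reaches. What this does not show is whether the swap carries over to the 2-substituted compounds, since the step from compound 2 to compound 1 cannot be read because both ends rest on a limit and not on a number: the limit of > 100000 nM in this assay, at which 2 of the 4 values shown sit.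

The compounds shown carry only bromo and fluoro on the phenyl ring, so it remains open how chloro, methoxy, a nitrile or a dimethylamino group would read at the same place on the shared core. Going by these compounds, it also remains open whether fluoro in place of bromo would give a step of similar size on any core other than this one, or at any other place on the phenyl ring where the values are not held at a limit.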